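The source may hold more compounds than are shown below. What is called first, only, known or untested is meant among the compounds shown, and "the series" means these compounds.

Working notes on the phthalazinone series.

Compound 1 `O=c1c2ccccc2c(Cc2ccc(Cl)cc2)nn1-c1ccc([N+](=O)[O-])cc1` is the reference for the change of interest. In a functional assay on aorta with Alpha-1D adrenergic receptor (Rattus norvegicus) as the target (a higher number here means that more compound is needed for the effect, a lower number that less compound is needed), compound 1 gives 29000 nM. Compound 2 `CSc1ccc(Cc2nn(-c3ccc([N+](=O)[O-])cc3)c(=O)c3ccccc23)cc1` carries methylsulfanyl in place of chloro on the benzyl ring, the change counted as methylsulfanyl in place of chloro on an aromatic carbon. In this assay compound 2 reaches only a limit, > 100000 nM, which is a limit of the assay and not a number. The step is therefore an at least 3.4-fold higher number from compound 1 to compound 2 (0.53 log units; beyond the scatter), an open-ended value because of the limit of > 100000 nM in this assay, at which 1 of the 3 values shown sits.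

Compound 3 `Cn1nc(Cc2ccc(Cl)cc2)c2ccccc2c1=O` differs from compound 1 at the core: methyl in place of 4-nitrophenyl on an aromatic nitrogen. In this assay compound 3 gives 430 nM, the step being a 67-fold lower number from compound 1 to compound 3 (1.83 log units; beyond the scatter). Within the data shown here, compound 3 thus holds the lowest number among the two numbers known here, the nearest being compound 1.

Compound 4 `CSc1ccc(Cc2nn(C)c(=O)c3ccccc23)cc1` has not yet been measured in this assay. It stands to compound 3 as compound 2 stands to compound 1: methylsulfanyl in place of chloro on an aromatic carbon. The two place descriptions match word for word, so this is the same change on a different core. Among the measured compounds shown here, the only prior reading of this change, from compound 1 to compound 2, went to a higher number and was cut off at the limit, so its true size is unknown; it is the sole instance and rests on one pair. For compound 4 a step of about a 4.2-fold higher number from compound 3 to compound 4 (0.62 log units; beyond the scatter) is expected, resting on the direction of an at least 3.4-fold higher number from compound 1 to compound 2 (0.53 log units; beyond the scatter). Compound 4 is accordingly estimated at 1800 nM, between 600 nM and 6000 nM. A measured number rather than a limit is thought more likely for compound 4, since compound 3 gives 430 nM, which leaves room.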

Compound 4, half-maximal effective concentration: 930 nM
Beside the measured number, compound 4's estimate is 1.9-fold (0.29 log units) above it, within the range that was stated.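

In this assay, methylsulfanyl in place of chloro on the core of compound 3 gives a 2.2-fold higher number from compound 3 to compound 4 (0.34 log units; beyond the scatter), so the direction seen on the core of compound 1 recurs, and the two readings stand as follows: the same change on two cores in this assay, an at least 3.4-fold higher number (0.53 log units; beyond the scatter) from compound 1 to compound 2 and a 2.2-fold higher number (0.34 log units; beyond the scatter) from compound 3 to compound 4; the limit leaves it open whether they differ

The other single change in this set, methyl in place of 4-nitrophenyl on an aromatic nitrogen, gives an at least 100-fold lower number from compound 2 to compound 4 (2.03 log units; beyond the scatter) and also keeps its direction on the second pair: the same change on two cores in this assay, a 67-fold lower number (1.83 log units; beyond the scatter) from compound 1 to compound 3 and an at least 100-fold lower number (2.03 log units; beyond the scatter) from compound 2 to compound 4; the limit leaves it open whether they differ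

Compound 2 stands at > 100000 nM, which is a limit of the assay and not a number, so these notes show a shared direction for the methylsulfanyl change but not a shared size, and two cores do not establish a rule for the wider series.

The compounds shown leave open how the aromatic carbon that carries chloro or methylsulfanyl would respond to other groups, such as an amine, a carboxylic acid or a longer chain. They also leave open how groups on the aromatic nitrogen other than methyl and 4-nitrophenyl, such as ethyl or an unsubstituted phenyl, would read in this assay.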